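Acyl variation on the shared core: cyclopropyl to cyclopentyl

This account rests on a few compounds, and the source may have more. Where it says the series, first, only, none or still open, it means among the compounds named here.

Measured so far:
compound 1, `CCCCC(=O)N1N=C(c2cc(Cl)ccc2N)SC1(C)C`, 12.6%
compound 2, `CC1(C)SC(c2cc(Cl)ccc2N)=NN1C(=O)C1CC1`, 23.2%

In an assay on isolated protein for inhibition of Nitric oxide synthase, inducible (Homo sapiens), read by scintillation counting, with a stated time of 30 min, tested at 50 uM (on this read-out lower numbers stand for less inhibition and higher numbers for more inhibition at the one concentration tested (going by the name of the read-out)), compound 2 stands highest of the two numbers; the nearest is compound 1, and the step of a number 10.6 percentage points higher from compound 1 to compound 2 (beyond the scatter) lies beyond the scatter but is modest.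

Compound 3, `CC1(C)SC(c2cc(Cl)ccc2N)=NN1C(=O)C1CCCC1`, is not yet measured. It differs from compound 2 in one place: cyclopentyl in place of cyclopropyl on a carbonyl carbon.

Among the measured compounds shown here, only one measured step bears on this change, the step from compound 1 to compound 2, in which an acyclic butyl gave way to a three-membered ring and the number rose by a modest amount. For the measured compounds named here, no step shows a five-membered ring on this carbonyl carbon, so the direction for compound 3 is open. The expectation is a step no larger than the scatter, a number 5.2 percentage points lower from compound 2 to compound 3 (within the scatter), possibly slightly downward.

Compound 3 is therefore estimated at 18%, with a range from 5% to 33%.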

Compound 3, a percentage reported as inhibition, at one concentration (the size of the read-out at that concentration, not a potency): 21.3%
Compound 3: middle estimate off by 3.3 percentage points, on the low side, within the range that was stated.
By their numbers in this assay, from the lowest: compounds 1, 3 and 2 (each within the scatter of the next, the first and the last beyond it).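

In this assay, replacing the three-membered ring with the five-membered one on the carbonyl carbon gives a number 1.9 percentage points lower from compound 2 to compound 3 (within the scatter), so among these two rings, ring size shows no effect that can be read at this position. Against the open-chain butyl, cyclopentyl gives a number 8.7 percentage points higher from compound 1 to compound 3 (within the scatter), whereas cyclopropyl gave a number 10.6 percentage points higher from compound 1 to compound 2 (beyond the scatter); the separation from butyl therefore holds beyond the scatter for cyclopropyl only, and the data do not support a general gain for carbocyclic acyl groups. No supporting measurement bears on why these groups compare in this way.

From the compounds shown here alone, it remains open whether a cyclohexyl or phenyl on this carbonyl carbon would separate from cyclopropyl and cyclopentyl. Going by these compounds, it also remains open whether an amine or carboxylic acid on the acyl group would change the read-out.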